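Cytotoxicity after Replacing an Amino Group with Phenoxy

This account rests on a few compounds, and the source may have more. Where it says the series, first, only, none or still open, it means among the compounds named here.

Compound 1 `CC(/C=N/Nc1ccc([N+](=O)[O-])cc1)=N\NC(=O)c1ccccc1`: > 100000 nM
Compound 2 `CC(/C=N/Nc1ccc([N+](=O)[O-])cc1)=N\NC(=O)c1ccccc1N`: 29800 nM

In an ADME assay on J774 cells (Mus musculus, strain BALB/c) for cytotoxicity, read by resazurin assay, with a stated time of 72 h (a lower number here means that less compound is tolerated, a higher number that more compound is tolerated), compound 1 reaches only a limit, > 100000 nM. Among the compounds with values here, compound 2 gives the sole number here, 29800 nM, so it stands as the one compound with a measured value, the other sitting at the limit of > 100000 nM in this assay, at which 1 of the 2 values shown sits. Within the data shown here, the step of an at least 3.3-fold lower number from compound 1 to compound 2 (0.52 log units; beyond the scatter) is the only measured change. Compound 3 `CC(/C=N/Nc1ccc([N+](=O)[O-])cc1)=N\NC(=O)c1ccccc1Oc1ccccc1` differs from compound 2 by phenoxy in place of amino on an aromatic carbon. Since the amino group that marked that step now leaves, the number is expected to move back toward the limit, a step of a 2.0-fold higher number from compound 2 to compound 3 (0.30 log units; within the scatter). Compound 3 is therefore estimated at 60000 nM, within 15000 nM to 200000 nM.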

Compound 3, half-maximal cytotoxic concentration: > 100000 nM
Compound 3 ended at the assay's limit (the forecaster's own chance of this, stated with the estimate: 40%); middle value at least 1.6-fold (0.22 log units) from the limit.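

In this assay phenoxy in place of amino gives an at least 3.3-fold higher number from compound 2 to compound 3 (0.52 log units; beyond the scatter) and so reverses the drop seen with amino. Among the three compounds, only the one carrying amino gives a measured number, and the much larger phenoxy on the same aromatic carbon brings no such drop. The step between compound 1 and compound 3 cannot be read: the limit of > 100000 nM in this assay, at which 2 of the 3 values shown sit.

Open, as far as these compounds go, is whether a methoxy or a methylamino group on this carbon would stay at the limit or follow amino. From the compounds shown here alone, how far compound 1 and compound 3 lie past the limit is also open.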